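Three Limits and a Fourth Compound Awaiting a Number

The source may report more compounds than this note shows. Statements on the series, on what has been measured and on what is new or still open speak of the compounds shown alone.

Compound 1, `CC(C)N(Cc1cccc(OCCCCCC(=O)O)c1)C(=O)c1ccc(-c2cccc(N(C)C)c2)cc1`, was tested in an ADME assay on HepG2 cells (Homo sapiens) for cytotoxicity, read by CellTiter-Glo and resazurin assay, with a stated time of 72 h (on this read-out lower numbers stand for an effect already at smaller amounts and higher numbers for an effect only at larger amounts of compound), and gave only a limit: compound 1 reads > 26000 nM. Its two closest neighbours fare the same. Compound 2, `CC(C)N(Cc1cccc(OCCCCCC(=O)O)c1)C(=O)c1ccc(-c2cccc(OCc3ccccc3)c2)cc1`, also reaches only a limit in this assay, with compound 2 at > 26000 nM. Compound 3, `COc1cccc(-c2ccc(C(=O)N(Cc3cccc(OCCCCCC(=O)O)c3)C(C)C)cc2)c1`, likewise stops at a limit, compound 3 giving > 26000 nM. The steps among them are therefore not readable in size: a step that the two limits leave unreadable from compound 1 to compound 2 with benzyloxy in place of dimethylamino on an aromatic carbon, a step that the two limits leave unreadable from compound 1 to compound 3 with methoxy in place of dimethylamino on an aromatic carbon, and a step that the two limits leave unreadable from compound 2 to compound 3 with hydrogen in place of phenyl on a saturated chain carbon bound to an oxygen on an aromatic ring. All that is known is the limit of > 26000 nM in this assay, at which 3 of the 3 values shown sit.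

Compound 4, `Cc1nnc(-c2cccc(-c3ccc(C(=O)N(Cc4cccc(OCCCCCC(=O)O)c4)C(C)C)cc3)c2)o1`, differs from compound 1 by 5-methyl-1,3,4-oxadiazol-2-yl in place of dimethylamino on an aromatic carbon. Among the compounds with values here, the steps that bear on it, from compound 1 to compound 2 and from compound 1 to compound 3, show only that changing this position leaves the value at the limit, so no step beyond the scatter is expected in this assay. The step from compound 1 to compound 4 is estimated as a step that the limit leaves unreadable from compound 1 to compound 4. Compound 4 is accordingly expected at about 40000 nM, within 15000 nM to 150000 nM, most likely reported again as a limit.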

Compound 4, half-maximal effective concentration: > 26000 nM
Compound 4: no number, only a limit; the forecaster's own chance of this, stated with the estimate: 85%; the middle value is on the limit's open side.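

In this assay compound 4 also gives only a limit, > 26000 nM. Within the data shown here, no step between compound 4 and compound 1, compound 2 or compound 3 can therefore be read in size. The compounds shown leave open whether the groups at this position differ at all in this read-out, since all that stands is this: the limit of > 26000 nM in this assay, at which 4 of the 4 values shown sit.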